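Compound 3: hydrogen for methyl on an aromatic nitrogen

The source may hold more compounds than are shown below. What is called first, only, known or untested is meant among the compounds shown, and "the series" means these compounds.

- compound 1 `COc1cc(C(=O)/C=C/c2c[nH]c3ccccc23)cc([N+](=O)[O-])c1OC` gives 1280 nM
- compound 2 `COc1cc(C(=O)/C=C/c2cn(C)c3ccccc23)cc(N)c1OC` gives 441 nM

In a functional assay on A2780 cells (Homo sapiens) for antiproliferative activity, read by MTT assay, with a stated time of 48 h (a lower number here means a stronger inhibitor, a higher number a weaker inhibitor), compound 2 holds the lower of the two numbers, with compound 1 beyond the scatter above it. Compound 3 `COc1cc(C(=O)/C=C/c2c[nH]c3ccccc23)cc(N)c1OC` differs from compound 2 by hydrogen in place of methyl on an aromatic nitrogen. Among the measured compounds shown here, compound 1 also carries hydrogen there but differs elsewhere too, so no measured step isolates this change. A modest rise in this assay, near the edge of the scatter, is expected, and the estimated 1.4-fold higher number from compound 2 to compound 3 (0.13 log units; within the scatter) reflects that. The estimate for compound 3 is 600 nM, with an expected range from 170 nM to 2000 nM.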

Compound 3, half-maximal inhibitory concentration: 351 nM
Compound 3: middle estimate off by 1.7-fold (0.23 log units), on the high side; low and high end bracket the measured number.
By their numbers in this assay, from the lowest: compounds 3 and 2 (each within the scatter of the next); then compound 1.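

In this assay hydrogen and methyl on the aromatic nitrogen cannot be told apart (a 1.3-fold lower number from compound 2 to compound 3 (0.10 log units; within the scatter)), so with the amino group in place this position shows no preference between the two. Amino in place of nitro on an aromatic carbon, by contrast, is a single change beyond the scatter (a 3.6-fold lower number from compound 1 to compound 3 (0.56 log units; beyond the scatter)). Nothing available accounts for either result. Open, going by these compounds, is whether a larger group on that nitrogen, such as ethyl or benzyl, would fit as well. Also open, on these data alone, is how an acetamide would compare with the amino group.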